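Nitrophenyl phenols with allyl groups: third member

The compounds below may be only part of what the source reports. "The series", "measured", "known", "first", "only" and "open" are said of these compounds alone.

Measured compounds in a functional assay on Lewis lung carcinoma cells (Mus musculus) for antiproliferative activity, read by MTT assay, with a stated time of 24 h; a higher number here means a weaker inhibitor, a lower number a stronger inhibitor:
compound 1, `C=CCc1cc(-c2cccc([N+](=O)[O-])c2)ccc1O`, > 100000 nM
compound 2, `C=CCOc1ccc(-c2cccc([N+](=O)[O-])c2)cc1CC=C`, > 100000 nM

Compound 1 gives only a limit of this assay, > 100000 nM. Compound 2 likewise gives only a limit, > 100000 nM. The step that the two limits leave unreadable from compound 1 to compound 2 thus cannot be read, as stated in the limit of > 100000 nM in this assay, at which 2 of the 2 values shown sit. Compound 3, `C=CCc1cc(-c2cccc([N+](=O)[O-])c2)cc(CC=C)c1O`, differs from compound 1 by allyl in place of hydrogen on an aromatic carbon. Among the measured compounds shown here, no measured step resolves such a change, and both known values sit at the limit. Compound 3 is therefore expected to remain at or near that limit, with an estimated step that the limit leaves unreadable from compound 1 to compound 3. The estimate for compound 3 is 150000 nM, range 30000 nM to 600000 nM.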

Compound 3, half-maximal inhibitory concentration: 56500 nM
Beside the measured number, compound 3's estimate is 2.7-fold (0.42 log units) above it; measured number inside the range.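

In this assay, among the compounds shown here, compound 3 gives 56500 nM, the first actual number. Allyl in place of hydrogen on an aromatic carbon ortho to a hydroxy group is thus the one change shown that leaves a readable value, with a step of an at least 1.7-fold lower number from compound 1 to compound 3 (0.24 log units; that floor lies within the scatter), so only a floor is known and it does not clear the scatter. The other two values remain limits: the limit of > 100000 nM in this assay, at which 2 of the 3 values shown sit.

On these data alone, the true size of this step stays open. So does how an amine or a longer chain at this position would read.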